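Fluoro for methyl on the aryl amide in two cores

This account rests on a few compounds, and the source may have more. Where it says the series, first, only, none or still open, it means among the compounds named here.

Measured so far in a functional assay on HeLa cells (Homo sapiens) for antiproliferative activity, read by MTT assay, with a stated time of 72 h; a higher number here means a weaker inhibitor, a lower number a stronger inhibitor:
compound 1 `Cc1ccc(N2C(=O)COc3ccc(-c4cnc5ccccc5c4)cc32)cc1` > 40000 nM
compound 2 `O=C1COc2ccc(-c3cnc4ccccc4c3)cc2N1c1ccc(F)cc1` 38800 nM
compound 3 `Cc1ccc(N2C(=O)COc3ccc(-c4cccc(NS(=O)(=O)c5ccc(F)cc5)c4)cc32)cc1` > 40000 nM

The value of compound 1 is a limit of the assay, not a number, as is the value of compound 3; (the limit of > 40000 nM in this assay, at which 2 of the 3 values shown sit). Compound 2 gives a number, and the step of an at least 1.0-fold lower number from compound 1 to compound 2 (0.01 log units; that floor lies within the scatter) comes from fluoro in place of methyl on an aromatic carbon. The difference between the two cores, that of compound 1 and that of compound 3, is not broken down here.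

Compound 4 `O=C1COc2ccc(-c3cccc(NS(=O)(=O)c4ccc(F)cc4)c3)cc2N1c1ccc(F)cc1` is not yet measured. It differs from compound 3 by fluoro in place of methyl on an aromatic carbon, the same change as that from compound 1 to compound 2. Compound 1 sits at a limit of the assay. Compound 2 gives 38800 nM. On that ground compound 4 is expected to show a step of a number no higher from compound 3 to compound 4 (the limit leaves the size open). Compound 4 is expected to give 40000 nM in this assay, within 20000 nM to 80000 nM.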

Compound 4, half-maximal inhibitory concentration: > 40000 nM
Compound 4 gave a limit, no number (the forecaster's own chance of this, stated with the estimate: 60%); the middle value sits exactly at the limit.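

Compound 3 and compound 4 both give a limit of the assay, not a number, so no step can be read between them: the limit of > 40000 nM in this assay, at which 3 of the 4 values shown sit.

Going by these compounds, whether fluoro in place of methyl on an aromatic carbon changes the activity of the core of compound 3 stays open.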